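From Fluoro to Isopropyl on a Shared Core

This account rests on a few compounds, and the source may have more. Where it says the series, first, only, none or still open, it means among the compounds named here.

For the measured compounds named here, compound 3 `Cc1cnc(Nc2ccc(F)cc2)nc1Nc1nc2ccccc2s1` is the one member of this small set without a firm number. In a functional assay on HeLa cells (Homo sapiens) for antiproliferative activity, read by MTT assay, with a stated time of 48 h (on this read-out higher numbers stand for weaker inhibition and lower numbers for stronger inhibition), compound 3 gives > 50000 nM, which is a limit of the assay and not a number. As far as these compounds go, compound 3 reaches only (the limit of > 50000 nM in this assay, at which 1 of the 3 values shown sits), so its true value is unknown. Compound 1 `Cc1cnc(Nc2ccc([N+](=O)[O-])cc2)nc1Nc1nc2ccccc2s1` gives 34300 nM, and compound 2 `Cc1cnc(Nc2ccc(S(C)(=O)=O)cc2)nc1Nc1nc2ccccc2s1` gives 460 nM. The change to compound 4 `Cc1cnc(Nc2ccc(C(C)C)cc2)nc1Nc1nc2ccccc2s1` is isopropyl in place of fluoro on an aromatic carbon. Going by the values given here, no measured step covers this swap directly. Among the compounds with values here, the nearest are an at least 100-fold higher number from compound 2 to compound 3 (2.03 log units; beyond the scatter) and an at least 1.4-fold higher number from compound 1 to compound 3 (0.16 log units; that floor lies within the scatter): the first shows that a swap on that aromatic carbon can move the number hugely, the second that it can also stay within the scatter. Lacking a closer guide, compound 4 is expected to stay near compound 3, a step that the limit leaves unreadable from compound 3 to compound 4, possibly again only a limit. The estimate for compound 4 is 60000 nM, within 10000 nM to 200000 nM.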

Compound 4, half-maximal inhibitory concentration: > 50000 nM
Compound 4: a limit, no number (the forecaster's own chance of this, stated with the estimate: 60%); the middle value lies beyond the limit too.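

Compound 4, like compound 3, stops at a limit in this assay, so the step between them cannot be read: the limit of > 50000 nM in this assay, at which 2 of the 4 values shown sit. What is new is that a carbon group, isopropyl, ends up where fluoro did: isopropyl in place of methylsulfonyl gives an at least 100-fold higher number from compound 2 to compound 4 (2.03 log units; beyond the scatter), while isopropyl in place of nitro gives an at least 1.4-fold higher number from compound 1 to compound 4 (0.16 log units; that floor lies within the scatter). Among the four groups shown on this aromatic carbon, methylsulfonyl alone gives a low number.

As far as these compounds go, whether an amine or a carboxylic acid here would come close to compound 2 remains open. From the compounds shown here alone, the true values of compound 3 and compound 4 also remain unknown.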